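Methyl ester in place of the terminal ketone on the chain

A few compounds are considered here, and "the series" means these few. Any claim that something is new, unique, unknown or untested is made for them only; others in the source may bear on it.

The two measured compounds share a core with an allyl group, an acetyl group and a hydroxyl on an aromatic ring. Compound 1, `C=CCc1cc(C(C)=O)c(O)cc1OCCCC`, carries a plain butoxy chain and in an assay on isolated protein for binding affinity to leukotriene B4 receptor 1 (Homo sapiens), tested at 1 uM (on this read-out higher numbers stand for more inhibition at the one concentration tested (going by the name of the read-out) and lower numbers for less inhibition), compound 1 gives 8%. Compound 2, `C=CCc1cc(C(C)=O)c(O)cc1OCCCCCC(C)=O`, extends that chain by a ketone-bearing tail, and in this assay compound 2 gives 58%, the higher of the two numbers, with the step of a number 50 percentage points higher from compound 1 to compound 2 (beyond the scatter).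

Compound 3, `C=CCc1cc(C(C)=O)c(O)cc1OCCCCCC(=O)OC`, differs from compound 2 by methoxy in place of methyl on a carbonyl carbon, turning the terminal ketone into a methyl ester. For the measured compounds named here, no measured step concerns this position: the only step known alters the chain end itself, not the group on its carbonyl carbon, so it gives no direct guide. Since the carbonyl that arrived with the large gain from compound 1 to compound 2 is kept, no step beyond the scatter is expected, a number 3 percentage points lower from compound 2 to compound 3 (within the scatter), and compound 3 is estimated at 55%, within 30% to 80%.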

Compound 3, a percentage reported as inhibition, at one concentration (the size of the read-out at that concentration, not a potency): 65%
Beside the measured number, compound 3's estimate is 10 percentage points below it; low and high end bracket the measured number.
By their numbers in this assay, from the lowest: compound 1; then compounds 2 and 3 (each within the scatter of the next).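

In this assay, the step is a number 7 percentage points higher from compound 2 to compound 3 (within the scatter) and so the swap of the terminal ketone for a methyl ester, with methoxy in place of methyl on a carbonyl carbon, leaves no change that can be told apart from the usual variation between repeats. Measured against the plain butoxy chain, the ester-bearing chain still gives a number 57 percentage points higher from compound 1 to compound 3 (beyond the scatter) and so the large gain first seen with compound 2 does not rest on the methyl of its ketone, since it appears with either of these two carbonyl-bearing chain ends. Nothing available here explains why these chain ends stand so far above the butoxy chain of compound 1.

Still open, going by these compounds, is whether the gain needs a carbonyl at the chain end at all, and how a carboxylic acid, an amide or an alcohol in that place would read. Also open, on these data alone, is how a shorter or longer chain would behave, and how compound 2 and compound 3 would compare as full potencies, since this read-out comes from one concentration only.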